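The source may hold more compounds than are shown below. What is called first, only, known or untested is meant among the compounds shown, and "the series" means these compounds.

Measured compounds in this series:
- compound 1 `COc1cc(C(N)=O)cc2nc(NC(=O)c3nccc4ccccc34)n(CCCNC(=O)OCc3ccccc3)c12`: > 100000 nM
- compound 2 `COc1cc(C(N)=O)cc2nc(NC(=O)c3cccnn3)n(CCCNC(=O)OCc3ccccc3)c12`: > 100000 nM
- compound 3 `COc1cc(C(N)=O)cc2nc(NC(=O)C3CCN(C)CC3)n(CCCNC(=O)OCc3ccccc3)c12`: > 100000 nM

In an assay for activation of interferon regulatory factor 3 (Homo sapiens), read by a luciferase reporter, with a stated time of 20 h (a lower number here means that less compound is needed, a higher number that more compound is needed for the effect), compound 2 gives only a limit, not a number. The same holds for compound 1 and for compound 3, each reported as a limit in this assay. All three values therefore sit at the limit of > 100000 nM in this assay, at which 3 of the 3 values shown sit, and none of the steps between them can be sized: a step that the two limits leave unreadable from compound 1 to compound 2, a step that the two limits leave unreadable from compound 1 to compound 3 and a step that the two limits leave unreadable from compound 2 to compound 3 are each unreadable. Where compound 2 stands is thus known only as a limit, with no ranking against compound 1 or compound 3.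

Compound 4 `COCCCOc1cc(C(N)=O)cc2nc(NC(=O)c3cccnn3)n(CCCNC(=O)OCc3ccccc3)c12` is not yet measured. It differs from compound 2 by 2-methoxyethyl in place of hydrogen on a saturated chain carbon bound to an oxygen on an aromatic ring. Among the measured compounds shown here, no measured step bears on this position; the three measured steps all concern the group on the carbonyl carbon and are unreadable in any case. There is thus no basis for expecting a step of any direction beyond the scatter from compound 2 to compound 4. The expectation for compound 4 is that it again reports a limit in this assay, and the estimated step of a number no higher from compound 2 to compound 4 (the limit leaves the size open) is taken as none. The estimate for compound 4 is 100000 nM, in the range 20000 nM to 300000 nM.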

Compound 4, half-maximal effective concentration: > 100000 nM
Compound 4 gave a limit, no number (the forecaster's own chance of this, stated with the estimate: 85%); the middle value lies on the limit itself.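

In this assay compound 4 reports a limit, as compound 2 does, and no step from compound 2 to compound 4 can be read: the limit of > 100000 nM in this assay, at which 4 of the 4 values shown sit.

The compounds shown leave open whether any of them reaches a measurable half-maximal effective concentration, and so whether the 2-methoxyethyl or the group on the carbonyl carbon alters the response at all.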